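This account rests on a few compounds, and the source may have more. Where it says the series, first, only, none or still open, it means among the compounds named here.

Of the compounds shown here, three have been measured in a functional assay on SK-MEL-28 cells (Homo sapiens) for inhibition, read by MTT assay, with a stated time of 48 h; a higher number here means a weaker inhibitor, a lower number a stronger inhibitor. Among the compounds with values here, compound 1 `C(=C/c1nc2ccccn2c1Sc1ccccc1)\c1ccccc1` gives 65400 nM in this assay, and compound 3 `CSc1ccc(-c2nc3ccccn3c2Sc2ccccc2)cc1` gives 67700 nM; the change a 1.0-fold higher number from compound 1 to compound 3 (0.02 log units; within the scatter) is the only single-point step among the measured compounds. Compound 2 `c1ccc(Sc2c(-c3ccccc3)nc3ccc(-c4ccccc4)cn23)cc1` gives > 100000 nM in this assay, which is a limit of the assay and not a number. Compound 2 thus stands at the limit of > 100000 nM in this assay, at which 1 of the 3 values shown sits, and the numbers shown say only that it lies there.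

Compound 4 `Clc1ccc2nc(-c3ccccc3)c(Sc3ccccc3)n2c1` differs from compound 2 by chloro in place of phenyl on an aromatic carbon. Within the data shown here, no measured step touches this position or this kind of exchange, so the one measured step, which lay within the scatter, gives no direction to expect. With compound 2 at a limit, only a weak inhibition is expected for compound 4, and the step of a number no higher from compound 2 to compound 4 (the limit leaves the size open) is an estimate without a measured precedent. Compound 4 is estimated to give 100000 nM in this assay, expected to fall between 40000 nM and 250000 nM.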

Compound 4, half-maximal inhibitory concentration: 76900 nM
Beside the measured number, compound 4's estimate is 1.3-fold (0.11 log units) above it, within the range that was stated.
By their numbers in this assay, from the lowest: compounds 1, 3 and 4 (each within the scatter of the next). At a limit, above all of these: compound 2.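

In this assay, within the data shown here, chloro in place of phenyl at this position gives an at least 1.3-fold lower number from compound 2 to compound 4 (0.11 log units; that floor lies within the scatter) and so provides the first measured exchange at this place on the shared core. The floor of that step lies within the scatter, so this result alone does not establish that chloro gives a stronger inhibitor here than phenyl. On these data alone, how far the two compounds stand apart stays open because compound 2 has a limit of the assay and not a number: the limit of > 100000 nM in this assay, at which 1 of the 4 values shown sits.

The compounds shown leave open how an amine, a carboxylic acid or a longer chain would read at this position. They also leave open whether chloro here would give a different number alongside the 2-phenylethenyl group of compound 1 or the 4-(methylsulfanyl)phenyl group of compound 3.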